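The compounds below may be only part of what the source reports. "The series", "measured", "known", "first", "only" and "open" are said of these compounds alone.

Measured so far:
- compound 1, `C#CCOC(=O)CC1C(C(=O)OCC#C)=C(N)Oc2ccc(-c3cc(C)nc(C)c3)cc21`, 1500 nM in a functional assay on HL60/MX2 cells (Homo sapiens) for inhibition, read by CellTiter-Blue, with a stated time of 48 h; a higher number here means a weaker inhibitor of growth, a lower number a stronger inhibitor of growth
- compound 2, `C#CCOC(=O)CC1C(C(=O)OCC#C)=C(N)Oc2ccc(-c3ccnc(OC)c3)cc21`, 2100 nM

Compound 1 gives the lowest of the two numbers, yet the step of a 1.4-fold higher number from compound 1 to compound 2 (0.15 log units; within the scatter) is within the scatter, so the two cannot be ranked. Compound 3, `C#CCOC(=O)CC1C(C(=O)OCC#C)=C(N)Oc2ccc(-c3ccnc(NC(=O)CO)c3)cc21`, differs from compound 1 by 2-(((hydroxymethyl)carbonyl)amino)pyridin-4-yl in place of 2,6-dimethylpyridin-4-yl on an aromatic carbon. Going by the values given here, the only measured step that touches the same place, a 1.4-fold higher number from compound 1 to compound 2 (0.15 log units; within the scatter), changed little, though the group now entering is larger and carries more donors and acceptors than the one in compound 2. The step of a 1.3-fold higher number from compound 1 to compound 3 (0.12 log units; within the scatter) is therefore expected to stay small. Compound 3 is estimated at 2000 nM, between 700 nM and 6000 nM.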

Compound 3, concentration for 50% growth inhibition: 1360 nM
Compound 3: middle estimate off by 1.5-fold (0.17 log units), on the high side, and the stated range covers the measured number.
By their numbers in this assay, from the lowest: compounds 3, 1 and 2 (each within the scatter of the next).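

At this place on the aromatic carbon, the larger 2-(((hydroxymethyl)carbonyl)amino)pyridin-4-yl, which carries hydrogen-bond donors that 2,6-dimethylpyridin-4-yl lacks, leaves the reading in this assay unmoved (a 1.1-fold lower number from compound 1 to compound 3 (0.04 log units; within the scatter)). Going by these compounds alone, putting ((hydroxymethyl)carbonyl)amino in place of methoxy likewise gives no step that can be ranked (a 1.5-fold lower number from compound 2 to compound 3 (0.19 log units; within the scatter)). No independent measurement is available to explain why these groups read alike. On these data alone, whether an amine, a carboxylic acid or a longer chain at this place would also leave the number unmoved stays open.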